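The source may report more compounds than this note shows. Statements on the series, on what has been measured and on what is new or still open speak of the compounds shown alone.

Series in a functional assay on MCF7 cells (Homo sapiens) for inhibition, read by CCK-8 assay, with a stated time of 48 h; a higher number here means a weaker inhibitor, a lower number a stronger inhibitor:
- compound 1 `COc1cc(-c2ccnc3cc(-c4ccc(C(F)(F)F)cc4)nn23)cc(OC)c1OC`: 2440 nM
- compound 2 `COc1cc(-c2ccnc3cc(-c4ccc(N(C)C)cc4)nn23)cc(OC)c1OC`: 44 nM
- compound 3 `COc1cc(-c2ccnc3cc(-c4ccc(C(C)=O)cc4)nn23)cc(OC)c1OC`: not yet measured

Compound 2 holds the lower of the two numbers, and its gap to compound 1 lies beyond the scatter. Compound 3 differs from compound 2 as follows: acetyl in place of dimethylamino on an aromatic carbon. Going by the values given here, only one measured step bears on this change, at the same place: a 55-fold lower number from compound 1 to compound 2 (1.74 log units; beyond the scatter). That step is large, with dimethylamino in place of trifluoromethyl. Compound 3 also lacks dimethylamino, so a clear rise beyond the scatter is expected in this assay, though a single pair cannot show where acetyl falls. The expected change is a 16-fold higher number from compound 2 to compound 3 (1.20 log units; beyond the scatter). For compound 3 the estimated value is 700 nM, with an expected range of 120 nM to 3000 nM.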

Compound 3, half-maximal inhibitory concentration: 5230 nM
Compound 3: the middle estimate sits 7.5-fold (0.87 log units) below what was measured; the measured number lies above the stated range.
By their numbers in this assay, from the lowest: compound 2; then compound 1; then compound 3.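

In this assay, the change from 4-(dimethylamino)phenyl to 4-acetylphenyl gives a 120-fold higher number from compound 2 to compound 3 (2.08 log units; beyond the scatter) even though dimethylamino and acetyl have the same counts of heavy atoms and hydrogen-bond acceptors, so those counts do not account for the low number of compound 2. Acetyl and trifluoromethyl lie much closer together, with a 2.1-fold higher number from compound 1 to compound 3 (0.33 log units; beyond the scatter) as a modest step beyond the scatter. Among the three groups on this aromatic carbon, dimethylamino alone gives a low number, and no measurement available here explains the difference.

As far as these compounds go, it remains open whether the low number depends on both methyl groups on the nitrogen. From the compounds shown here alone, the standing of an unsubstituted amine, a morpholine ring or a methoxy group at the same place also remains open.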